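Removing the bromo group from a thiourea thioether series

A few compounds are considered here, and "the series" means these few. Any claim that something is new, unique, unknown or untested is made for them only; others in the source may bear on it.

Compound 1 `CNC(=O)c1ccc(Sc2ccc(NC(=S)Nc3cc(C(F)(F)F)cc(C(F)(F)F)c3)cc2)nc1` gives 16600 nM in a functional assay on HCT-116 cells (Homo sapiens) for cytotoxicity, read by MTT assay, with a stated time of 48 h; a higher number here means a weaker inhibitor, a lower number a stronger inhibitor
Compound 2 `CNC(=O)c1ccc(Sc2ccc(NC(=S)Nc3cccc(C)c3)cc2)nc1` gives 52400 nM in this assay
Compound 3 `CNC(=O)c1ccc(Sc2cccc(NC(=S)Nc3ccc(Br)c(C(F)(F)F)c3)c2)nc1` gives 16500 nM in this assay

Compound 3 and compound 1 sit within the scatter of each other in this assay and so cannot be ordered, while compound 2 lies beyond the scatter from compound 3 with the higher number. The step from compound 3 to compound 4 `CNC(=O)c1ccc(Sc2cccc(NC(=S)Nc3cccc(C(F)(F)F)c3)c2)nc1` is a single change, hydrogen in place of bromo on an aromatic carbon on the ring that carries the thiourea. For the measured compounds named here, no step between two measured compounds isolates this change, so the expected size rests only on the three numbers given. Since the trifluoromethyl group stays in place, and compound 1 with two such groups gives 16600 nM close to compound 3, the loss of the bromo group is expected to cost some potency, but a modest amount. The expected step is a 1.6-fold higher number from compound 3 to compound 4 (0.20 log units; within the scatter) in this assay and is an estimate only. In this assay compound 4 is expected to give 26000 nM with a range from 11000 nM to 65000 nM around that estimate.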

Compound 4, half-maximal inhibitory concentration: 16200 nM
Compound 4: the middle estimate sits 1.6-fold (0.21 log units) above what was measured; low and high end bracket the measured number.
By their numbers in this assay, from the lowest: compounds 4, 3 and 1 (each within the scatter of the next); then compound 2.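

In this assay, for the compounds shown here, hydrogen in place of bromo on this aromatic carbon, ortho to a trifluoromethyl group and para to a large group, gives a 1.0-fold lower number from compound 3 to compound 4 (0.01 log units; within the scatter), the only comparison here that isolates a single change. At this position, therefore, the read-out does not separate bromo from hydrogen, and removing that one heavy atom leaves the number within the scatter. No supporting data bear on why this exchange leaves the number within the scatter.

From the compounds shown here alone, it remains open whether other groups on this carbon, such as an amine, a methoxy group or a carboxylic acid, would also stay within the scatter of compound 4. Also open, going by these compounds, is whether the trifluoromethyl group that remains in compound 4 could be replaced by hydrogen or a nitrile without a step beyond the scatter.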